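Methyl on the oxime oxygen of compound 3

The source may hold more compounds than are shown below. What is called first, only, known or untested is meant among the compounds shown, and "the series" means these compounds.

Compound 1 `O/N=C(\CCN1CCN(c2ccccn2)CC1)c1ccccc1` gives 70% in a functional assay on HEK293 cells with D(4) dopamine receptor (Homo sapiens) as the target, read by FLIPR; a lower number here means a smaller maximal response, a higher number a larger maximal response. Compound 2 `Cc1cccc(/C(CCN2CCN(c3ccccn3)CC2)=N/O)c1` gives 74% in this assay; a number 4 percentage points higher from compound 1 to compound 2 (within the scatter). Compound 3 `O/N=C(\CCN1CCN(c2ccccn2)CC1)c1ccc(Cl)cc1` gives 46% in this assay and stands lowest of the three measured values: a number 24 percentage points lower from compound 1 to compound 3 (beyond the scatter) and a number 28 percentage points lower from compound 2 to compound 3 (beyond the scatter). Compound 4 `CO/N=C(\CCN1CCN(c2ccccn2)CC1)c1ccc(Cl)cc1` differs from compound 3 by methyl in place of hydrogen on an oxygen. Among the compounds with values here, every measured step so far concerns the aromatic ring; none alters the oxygen, so no step speaks directly to this change. From the compounds shown here alone, without such a precedent, no step beyond the scatter is expected in this assay for compound 4, and the direction remains open. Compound 4 is therefore estimated at 46%, range 26% to 66%, which means an expected no change at the digits printed from compound 3 to compound 4 (within the scatter).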

Compound 4, largest response reached (reported as efficacy), in percent of the reference or control that the assay uses: 87%
The estimate for compound 4 lay 41 percentage points below the measured number; measured number outside the range, above it.
By their numbers in this assay, from the lowest: compound 3; then compounds 1 and 2 (each within the scatter of the next); then compound 4.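

The oxime oxygen is a sensitive position in this assay, not only the aromatic ring: hydroxy to methoxy gives a number 41 percentage points higher from compound 3 to compound 4 (beyond the scatter) and so runs opposite to the chloro step, a number 24 percentage points lower from compound 1 to compound 3 (beyond the scatter). In this pair, a single methyl on that oxygen is enough to change the maximal response beyond the scatter. Nothing available here explains the rise.

From the compounds shown here alone, whether methoxy acts the same way on the unsubstituted phenyl of compound 1 or the 3-methylphenyl of compound 2 remains open. So does what an ethyl or benzyl group on that oxygen would give.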